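A few compounds are considered here, and "the series" means these few. Any claim that something is new, unique, unknown or untested is made for them only; others in the source may bear on it.

The shared core carries two side groups that vary across these compounds. Compound 1 `COc1ncnc2c1c(-c1ccsc1)cn2[C@@H]1O[C@H](CO)[C@@H](O)[C@H]1O` carries a methoxy and a thiophen-3-yl group, and in a functional assay on HCT-116 cells (Homo sapiens), read by MTT assay, with a stated time of 72 h (a lower number here means a stronger inhibitor, a higher number a weaker inhibitor), compound 1 gives 140 nM. Compound 2 `CNc1ncnc2c1c(-c1ccsc1)cn2[C@@H]1O[C@H](CO)[C@@H](O)[C@H]1O` differs from compound 1 by methoxy in place of methylamino on an aromatic carbon. For compound 2 this assay reports only a limit, > 20000 nM. The step of an at least 140-fold lower number from compound 2 to compound 1 (2.15 log units; beyond the scatter) is therefore large. Compound 3 `CNc1ncnc2c1c(-c1ccco1)cn2[C@@H]1O[C@H](CO)[C@@H](O)[C@H]1O` differs from compound 2 by furan-2-yl in place of thiophen-3-yl on an aromatic carbon, and in this assay compound 3 gives 440 nM. The step of an at least 45-fold lower number from compound 2 to compound 3 (1.65 log units; beyond the scatter) is large as well.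

Compound 4 `COc1ncnc2c1c(-c1ccco1)cn2[C@@H]1O[C@H](CO)[C@@H](O)[C@H]1O` has not yet been measured. It differs from compound 3 by methoxy in place of methylamino on an aromatic carbon, the same change as that from compound 2 to compound 1, and the place is described in the same words, so it counts as the same change. A step of an at least 140-fold lower number from compound 2 to compound 1 (2.15 log units; beyond the scatter) was measured from a limit, so only its lower bound is known. From compound 3, which already gives a low number, a smaller but still favourable step a 7.3-fold lower number from compound 3 to compound 4 (0.87 log units; beyond the scatter) is expected. Compound 4 is thus estimated at 60 nM, likely between 10 nM and 300 nM.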

Compound 4, half-maximal inhibitory concentration: 40 nM
The estimate for compound 4 lay 1.5-fold (0.18 log units) above the measured number; the measured number falls inside the stated range.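

In this assay, methoxy in place of methylamino again lowers the number, with an 11-fold lower number from compound 3 to compound 4 (1.04 log units; beyond the scatter), so the direction of this change carries over from one core to the other but its size does not: the same change on two cores in this assay, an at least 140-fold lower number (2.15 log units; beyond the scatter) from compound 2 to compound 1 and an 11-fold lower number (1.04 log units; beyond the scatter) from compound 3 to compound 4, at least 12-fold (1.11 log units) apart, beyond the scatter of two such steps

Furan-2-yl in place of thiophen-3-yl behaves in the same way, with a 3.5-fold lower number from compound 1 to compound 4 (0.54 log units; beyond the scatter), again keeping the direction while the size differs: the same change on two cores in this assay, an at least 45-fold lower number (1.65 log units; beyond the scatter) from compound 2 to compound 3 and a 3.5-fold lower number (0.54 log units; beyond the scatter) from compound 1 to compound 4, at least 12-fold (1.11 log units) apart, beyond the scatter of two such steps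

These four compounds do not show why the sizes differ, and both comparisons lean on compound 2, whose value is a limit and not a number: the limit of > 20000 nM in this assay, at which 1 of the 4 values shown sits.

The compounds shown leave open whether methoxy would again give the lower number beside a phenyl or pyridine group in place of the thiophen-3-yl or furan-2-yl group. They also leave open how an ethoxy or dimethylamino group, put where methoxy and methylamino sit, would read in this assay.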